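Fluorinated versus methylated amide caps on a shared core

The compounds below may be only part of what the source reports. "The series", "measured", "known", "first", "only" and "open" are said of these compounds alone.

Measured compounds in a functional assay on MDA-MB-231 cells (Homo sapiens) for antiproliferative activity, read by CCK-8 assay, with a stated time of 72 h; on this read-out higher numbers stand for weaker inhibition and lower numbers for stronger inhibition:
- compound 1 `O=C(Nc1cccc(-c2oc3cc(-c4ccc(F)cc4)ccc3c(=O)c2O)c1)c1ccccc1F` gives 7240 nM
- compound 2 `O=C(Nc1cccc(-c2oc3cc(-c4ccc(F)cc4)ccc3c(=O)c2O)c1)c1ccc(F)cc1F` gives 11200 nM
- compound 3 `Cc1cccc(C(=O)Nc2cccc(-c3oc4cc(-c5ccc(F)cc5)ccc4c(=O)c3O)c2)c1` gives 2840 nM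

All three share one core and differ only in the aryl group on the amide carbonyl. Compound 3 has the lowest number of the three; its steps to the other two lie beyond the scatter, so it is the strongest inhibitor shown. Compound 4 `O=C(Nc1cccc(-c2oc3cc(-c4ccc(F)cc4)ccc3c(=O)c2O)c1)c1cc(F)cc(F)c1` is not yet measured; it differs from compound 3 in one place: 3,5-difluorophenyl in place of 3-methylphenyl on a carbonyl carbon

Going by the values given here, three measured steps bear on this change. The step of a 1.5-fold higher number from compound 1 to compound 2 (0.19 log units; within the scatter) shows that fluoro in place of hydrogen barely moved the number. The steps of a 2.5-fold lower number from compound 1 to compound 3 (0.41 log units; beyond the scatter) and a 3.9-fold lower number from compound 2 to compound 3 (0.60 log units; beyond the scatter) show that fluorinated phenyls gave higher numbers than 3-methylphenyl, the difluorophenyl most of all. Going back from 3-methylphenyl to a difluorophenyl is therefore expected to raise the number by a modest step, a 2.3-fold higher number from compound 3 to compound 4 (0.36 log units; beyond the scatter). Compound 4 is expected to give about 6500 nM, with a likely range from 2500 nM to 16000 nM.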

Compound 4, half-maximal inhibitory concentration: 2440 nM
Compound 4: middle estimate off by 2.7-fold (0.43 log units), on the high side; the whole stated range lies above it.
By their numbers in this assay, from the lowest: compounds 4 and 3 (each within the scatter of the next); then compounds 1 and 2 (each within the scatter of the next).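

In this assay, going by these compounds alone, the earlier compounds linked fluorinated phenyl groups on this carbonyl carbon with higher numbers, but a 1.2-fold lower number from compound 3 to compound 4 (0.07 log units; within the scatter) shows that 3,5-difluorophenyl and 3-methylphenyl cannot be told apart here, so fluoro groups on this ring do not by themselves raise the number. Among these compounds the placing of the fluoro groups matters: a 4.6-fold lower number from compound 2 to compound 4 (0.66 log units; beyond the scatter) separates two difluorophenyl groups that differ only in that placing, and a 3.0-fold lower number from compound 1 to compound 4 (0.47 log units; beyond the scatter) also sets 3,5-difluorophenyl apart from 2-fluorophenyl. Nothing measured here explains these differences. From the compounds shown here alone, it remains open how 3,5-dimethylphenyl or 3-chlorophenyl would compare on this carbonyl carbon. A phenyl carrying an amine or a carboxylic acid is also untested among the compounds shown, so it is unknown whether this position accepts such groups.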